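Propyl for propylsulfanyl on the shared adenine-type core

A few compounds are considered here, and "the series" means these few. Any claim that something is new, unique, unknown or untested is made for them only; others in the source may bear on it.

Compound 1 `CCCSc1nc(N)c2nc(O)n(Cc3ccccc3)c2n1`: 0.01 uM in a functional assay (spleen, spleen) for activation, with Mus musculus as the target; on this read-out higher numbers stand for an effect only at larger amounts of compound and lower numbers for an effect already at smaller amounts
Compound 2 `Cc1ccc(Cn2c(O)nc3c(N)ncnc32)cc1`: 10 uM in this assay

Compound 1 stands lowest of the two numbers; compound 2 sits far higher, well beyond the scatter. Compound 3 `CCCc1nc(N)c2nc(O)n(Cc3ccccc3)c2n1` differs from compound 1 in one place: propyl in place of propylsulfanyl on an aromatic carbon. Within the data shown here, no step between two measured compounds isolates such a change, so the size is uncertain; a small shift toward higher concentration, near the edge of the scatter, is expected. The step of a 3.0-fold higher number from compound 1 to compound 3 (0.48 log units; beyond the scatter) is the expected outcome. Compound 3 is estimated at 0.03 uM in this assay, with a range of 0.005 uM to 0.2 uM.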

Compound 3, minimum effective concentration: 1 uM
Compound 3: the middle estimate sits 33-fold (1.52 log units) below what was measured; the measured number lies above the stated range.
By their numbers in this assay, from the lowest: compound 1; then compound 3; then compound 2.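

Propyl in place of propylsulfanyl, on the aromatic carbon between two ring nitrogen atoms, gives a 100-fold higher number from compound 1 to compound 3 (2.00 log units; beyond the scatter) in this assay and is the first step in the series to isolate this position. The three-carbon chain stays, so the two groups differ by the sulfur atom, and that difference alone goes with a large step. Nothing at hand explains the size of this step. As far as these compounds go, whether propoxy or propylamino would match compound 1 stays open, as does the effect of a longer chain such as butylsulfanyl.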